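Moving from 2,4-difluorophenyl to 2,5-difluorophenyl: working notes

The source may hold more compounds than are shown below. What is called first, only, known or untested is meant among the compounds shown, and "the series" means these compounds.

Values so far in a functional assay with Homo sapiens as the target; on this read-out lower numbers stand for stronger inhibition and higher numbers for weaker inhibition:
- compound 1 `CC(C)[C@H](NC(=O)COc1cccc2ccccc12)C(=O)N[C@@H](CC(=O)O)C(=O)COc1cccc(F)c1`: 12000 nM
- compound 2 `CC(C)[C@H](NC(=O)COc1cccc2ccccc12)C(=O)N[C@@H](CC(=O)O)C(=O)COc1ccc(F)cc1F`: 17600 nM

Within the data shown here, only two values are in hand, and compound 2 at 17600 nM lies within the scatter of compound 1. The next structure, compound 3 `CC(C)[C@H](NC(=O)COc1cccc2ccccc12)C(=O)N[C@@H](CC(=O)O)C(=O)COc1cc(F)ccc1F`, keeps the shared core and changes one group: 2,5-difluorophenyl in place of 2,4-difluorophenyl on an oxygen on a saturated carbon. In words, 2,5-difluorophenyl stands in place of 2,4-difluorophenyl on an oxygen on a saturated carbon. Among the measured compounds shown here, the one measured step that bears on this is a 1.5-fold higher number from compound 1 to compound 2 (0.17 log units; within the scatter), which also changes only the fluorinated phenyl group at that place. For the measured compounds named here, no measured compound carries the 2,5-difluorophenyl group yet, so no step beyond the scatter is expected in this assay, and no direction is favoured. The expected step is a 1.2-fold lower number from compound 2 to compound 3 (0.07 log units; within the scatter). For compound 3 the estimated value is 15000 nM, with an expected range of 6500 nM to 35000 nM.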

Compound 3, half-maximal inhibitory concentration: 19700 nM
Estimate against measurement, compound 3: 1.3-fold (0.12 log units) below, within the range that was stated.
By their numbers in this assay, from the lowest: compounds 1, 2 and 3 (each within the scatter of the next).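

In this assay, the same atoms joined differently in the fluorinated phenyl group on an oxygen on a saturated carbon give a 1.1-fold higher number from compound 2 to compound 3 (0.05 log units; within the scatter), so 2,4-difluorophenyl and 2,5-difluorophenyl are not told apart at this place. Fluoro in place of hydrogen on an aromatic carbon gives a 1.6-fold higher number from compound 1 to compound 3 (0.22 log units; within the scatter), so this added fluoro also produces no step beyond the scatter. No measured information here bears on why these compounds are not separated.

As far as these compounds go, all three compounds carry only fluoro on this phenyl group, so whether a chloro, a methoxy or an amine there would give a step beyond the scatter stays open. Also open, from the compounds shown here alone, is how an unsubstituted phenyl group at this place would compare with the fluorinated groups.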